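A Methoxyphenyl Group in Place of Pyridin-2-yl

The source may report more compounds than this note shows. Statements on the series, on what has been measured and on what is new or still open speak of the compounds shown alone.

Measured compounds:
compound 1, `CCN1CCN(CC(=O)Nc2nc3ccccc3[nH]2)CC1`, in a functional assay, read by spectrophotometry, with a stated time of 30 min, tested at 50 ug/mL; on this read-out higher numbers stand for a stronger effect at the one concentration tested and lower numbers for a weaker effect: 35.7%
compound 2, `O=C(CN1CCN(c2ccccc2)CC1)Nc1nc2ccccc2[nH]1`, in this assay: 24.1%
compound 3, `O=C(CN1CCN(c2ccccn2)CC1)Nc1nc2ccccc2[nH]1`, in this assay: 50%

Compound 3 stands highest of the three in this assay: the step of a number 14.3 percentage points higher from compound 1 to compound 3 (beyond the scatter) and the step of a number 25.9 percentage points higher from compound 2 to compound 3 (beyond the scatter) both lie beyond the scatter, so compound 3 is the most active of the measured set. Compound 4, `COc1ccc(N2CCN(CC(=O)Nc3nc4ccccc4[nH]3)CC2)cc1`, is not yet measured. It differs from compound 3 in one place: 4-methoxyphenyl in place of pyridin-2-yl on an amine nitrogen in a ring.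

Going by the values given here, two measured steps bear on this change. The step of a number 25.9 percentage points higher from compound 2 to compound 3 (beyond the scatter) shows that an all-carbon aromatic ring on this ring nitrogen gave a weaker read-out than pyridin-2-yl, and the step of a number 11.6 percentage points lower from compound 1 to compound 2 (beyond the scatter) shows phenyl below ethyl as well. Among the compounds with values here, compound 4 carries an all-carbon ring, so a step downward beyond the scatter is expected, though the methoxy substituent has no measured counterpart here and leaves the size uncertain. Compound 4 is therefore expected to give about 30% in this assay, within 15% to 48%. This estimate means a step of a number 20 percentage points lower from compound 3 to compound 4 (beyond the scatter).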

Compound 4, a percentage reported as activity, at one concentration (the size of the read-out at that concentration, not a potency): 25.8%
For compound 4 the middle estimate is 4.2 percentage points above the measured one; low and high end bracket the measured number.
By their numbers in this assay, from the lowest: compounds 2, 4 and 1 (each within the scatter of the next, the first and the last beyond it); then compound 3.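

In this assay, methoxy in place of hydrogen on an aromatic carbon gives a number 1.7 percentage points higher from compound 2 to compound 4 (within the scatter) and thus adds nothing readable to the phenyl ring, while the gap to the heteroaromatic group remains, with a number 24.2 percentage points lower from compound 3 to compound 4 (beyond the scatter) for 4-methoxyphenyl in place of pyridin-2-yl. Against ethyl, the same group gives a number 9.9 percentage points lower from compound 1 to compound 4 (within the scatter) and so cannot be told apart from ethyl on this ring nitrogen, whereas phenyl could, with a number 11.6 percentage points lower from compound 1 to compound 2 (beyond the scatter) on that step. No evidence at hand accounts for these numbers.

The compounds shown leave open whether a pyridin-3-yl or pyrimidin-2-yl group on this ring nitrogen would keep the read-out of compound 3 at 50% in this assay. As far as these compounds go, each compound is also seen at a single concentration, so how they would rank as potencies remains unknown.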